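Anilide in place of ester on a triazolylthioacetyl side chain

This account rests on a few compounds, and the source may have more. Where it says the series, first, only, none or still open, it means among the compounds named here.

Measured compounds:
compound 1 `CCOC(=O)CSc1nnc(-c2cc(OC)c(OC)c(OC)c2)n1-c1ccc(OC)cc1` — > 60000 nM
compound 2 `COc1ccc(NC(=O)CSc2nnc(-c3cc(OC)c(OC)c(OC)c3)n2-c2ccc(OC)cc2)cc1` — 45300 nM
compound 3 `CCOC(=O)CSc1nnc(-c2cc(OC)c(OC)c(OC)c2)n1-c1ccc(N(C)C)cc1` — 28800 nM

In a functional assay on HT-29 cells (Homo sapiens) for inhibition, read by MTT assay, with a stated time of 48 h (on this read-out lower numbers stand for stronger inhibition and higher numbers for weaker inhibition), compound 1 reaches only a limit, (the limit of > 60000 nM in this assay, at which 1 of the 3 values shown sits), and no number. In this assay compound 2 gives 45300 nM, and compound 3 gives 28800 nM. The change from compound 1 to compound 2 is (4-methoxyphenyl)amino in place of ethoxy on a carbonyl carbon, and it made an at least 1.3-fold lower number from compound 1 to compound 2 (0.12 log units; that floor lies within the scatter); the floor on that step comes because of the limit of > 60000 nM in this assay, at which 1 of the 3 values shown sits. The cores of compound 3 and compound 1 differ by dimethylamino in place of methoxy on an aromatic carbon, a change that made an at least 2.0-fold lower number from compound 1 to compound 3 (0.31 log units; beyond the scatter).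

Compound 4 `COc1ccc(NC(=O)CSc2nnc(-c3cc(OC)c(OC)c(OC)c3)n2-c2ccc(N(C)C)cc2)cc1` is not yet measured in this assay. Among the compounds with values here, it differs from compound 3 by (4-methoxyphenyl)amino in place of ethoxy on a carbonyl carbon, the same change as the one from compound 1 to compound 2, at the same place. That earlier step set only a floor, so the step to compound 4 is expected to be of similar modest size, a 1.6-fold lower number from compound 3 to compound 4 (0.20 log units; within the scatter). On that basis compound 4 is estimated at 18000 nM in this assay, within 8000 nM to 45000 nM.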

Compound 4, half-maximal inhibitory concentration: 51400 nM
Estimate against measurement, compound 4: 2.9-fold (0.46 log units) below; the measured number lies above the stated range.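

In this assay, (4-methoxyphenyl)amino in place of ethoxy on the carbonyl carbon, carried to the core of compound 3, gives a 1.8-fold higher number from compound 3 to compound 4 (0.25 log units; within the scatter), and set beside the earlier step it reads: the same change on two cores in this assay, an at least 1.3-fold lower number (0.12 log units; that floor lies within the scatter) from compound 1 to compound 2 and a 1.8-fold higher number (0.25 log units; within the scatter) from compound 3 to compound 4; the limit leaves it open whether they differ. Dimethylamino in place of methoxy on an aromatic carbon, carried to the core of compound 2, gives a 1.1-fold higher number from compound 2 to compound 4 (0.05 log units; within the scatter), and set beside the earlier step it reads: the same change on two cores in this assay, an at least 2.0-fold lower number (0.31 log units; beyond the scatter) from compound 1 to compound 3 and a 1.1-fold higher number (0.05 log units; within the scatter) from compound 2 to compound 4; the limit leaves it open whether they differ. Compound 1 gives only a limit, > 60000 nM, and the pairs show neither that these changes carry over from one core to the other nor that they fail to.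

The compounds shown leave open what other groups on the carbonyl carbon would give, such as a hydroxyl, which would make a carboxylic acid, or a simple alkylamine. They also leave open whether a group such as chloro or morpholino, in place of methoxy or dimethylamino on that aromatic carbon, would give a number clearly apart from these.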